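A few compounds are considered here, and "the series" means these few. Any claim that something is new, unique, unknown or untested is made for them only; others in the source may bear on it.

Compound 1, `Fc1ccccc1COc1ccc(-c2cc(CN3CCN(Cc4ccc(C(F)(F)F)cc4)CC3)no2)cc1`, gives 3000 nM.
Compound 2, `N#Cc1cccc(COc2ccc(-c3cc(CN4CCN(c5ccc(F)cc5)CC4)no3)cc2)c1`, gives 2400 nM.

In a functional assay on MCF7 cells (Homo sapiens) for antiproliferative activity, read by sulforhodamine B assay, with a stated time of 72 h (a lower number here means a stronger inhibitor, a higher number a weaker inhibitor), compound 2 gives the lower of the two numbers, but the gap to compound 1 lies within the usual scatter, so the two are not told apart. Compound 3, `CC(C)(C)OC(=O)N1CCN(Cc2cc(-c3ccc(OCc4cccc(C#N)c4)cc3)on2)CC1`, carries tert-butoxycarbonyl in place of 4-fluorophenyl on an amine nitrogen in a ring. Among the measured compounds shown here, no step between measured compounds is known, so the size of this change can only be guessed; a modest weakening seems the more likely direction, though a result within the scatter would not surprise. Compound 3 is expected to give 5000 nM, with a range from 1500 nM to 16000 nM, meaning an expected step of a 2.1-fold higher number from compound 2 to compound 3 (0.32 log units; beyond the scatter).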

Compound 3, half-maximal inhibitory concentration: 3800 nM
Compound 3: the middle estimate sits 1.3-fold (0.12 log units) above what was measured, and the stated range covers the measured number.
By their numbers in this assay, from the lowest: compounds 2, 1 and 3 (each within the scatter of the next).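

In this assay, tert-butoxycarbonyl in place of 4-fluorophenyl on the amine nitrogen in the ring gives a 1.6-fold higher number from compound 2 to compound 3 (0.20 log units; within the scatter), so the two compounds are not told apart. For this pair, then, a group with an aromatic ring and a group with no ring but with hydrogen-bond acceptors, both of the same heavy-atom count, read alike at this position. No measurement at hand offers an explanation for this. From the compounds shown here alone, whether a small methyl group or a chain ending in a carboxylic acid on this nitrogen would shift the number beyond the scatter stays open.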